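Fluorine swap on the cinnamide arm: compound 1 to compound 4

The compounds below may be only part of what the source reports. "The series", "measured", "known", "first", "only" and "open" are said of these compounds alone.

Values in a functional assay on HT-29 cells (Homo sapiens) for inhibition, read by MTT assay, with a stated time of 48 h; on this read-out higher numbers stand for weaker inhibition and lower numbers for stronger inhibition:
- compound 1 `COc1cc(/C=C/c2ccc(NC(=O)/C=C/c3cc(OC)c(O)c(OC)c3)cc2)cc(OC)c1`: 3080 nM
- compound 2 `COc1cc(/C=C/c2ccc(NC(=O)/C=C/c3ccc(C(F)(F)F)cc3)cc2)cc(OC)c1`: 1780 nM
- compound 3 `COc1cc(/C=C/c2ccc(NC(=O)/C=C/c3ccc(F)cc3)cc2)cc(OC)c1`: 11600 nM
- compound 4 `COc1cc(/C=C/c2ccc(NC(=O)/C=C/c3cccc(F)c3)cc2)cc(OC)c1`: not yet measured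

Compound 1 stands close to compound 2 and well apart from compound 3. The nearest neighbour gives a 1.7-fold lower number from compound 1 to compound 2 (0.24 log units; within the scatter), and the furthest gives a 3.8-fold higher number from compound 1 to compound 3 (0.58 log units; beyond the scatter).

Compound 4 keeps the core of compound 1 and carries 3-fluorophenyl in place of 4-hydroxy-3,5-dimethoxyphenyl on a double-bonded chain carbon bound to a double-bonded chain carbon.

For the measured compounds named here, the closest precedent is the change to 4-fluorophenyl, a 3.8-fold higher number from compound 1 to compound 3 (0.58 log units; beyond the scatter). The change to 4-(trifluoromethyl)phenyl gave a 1.7-fold lower number from compound 1 to compound 2 (0.24 log units; within the scatter), so removing 4-hydroxy-3,5-dimethoxyphenyl does not by itself move the number beyond the scatter. Fluoro in place of trifluoromethyl gave a 6.5-fold higher number from compound 2 to compound 3 (0.81 log units; beyond the scatter). Going by the values given here, no measured compound carries 3-fluorophenyl, so the transfer from compound 3 at 11600 nM is uncertain. In this assay a modest move towards a higher number is expected, about the size of the scatter and smaller than the step to the 4-fluorophenyl compound. The estimated step is a 1.9-fold higher number from compound 1 to compound 4 (0.29 log units; within the scatter). The estimate for compound 4 is 6000 nM, with an expected range from 2200 nM to 14000 nM.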

Compound 4, half-maximal inhibitory concentration: 16800 nM
The estimate for compound 4 lay 2.8-fold (0.45 log units) below the measured number, and the stated range ends below it.
By their numbers in this assay, from the lowest: compounds 2 and 1 (each within the scatter of the next); then compounds 3 and 4 (each within the scatter of the next).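

In this assay, the fluoro group on this ring reads the same in both printed forms: 3-fluorophenyl in place of 4-fluorophenyl gives a 1.4-fold higher number from compound 3 to compound 4 (0.16 log units; within the scatter), so the two fluorophenyl compounds form one group. The change from 4-hydroxy-3,5-dimethoxyphenyl to a fluorophenyl now rests on two compounds, with the new case giving a 5.5-fold higher number from compound 1 to compound 4 (0.74 log units; beyond the scatter), although compound 2 goes against any reading that losing 4-hydroxy-3,5-dimethoxyphenyl alone raises the number, and the replacement group itself matters, as a 9.4-fold higher number from compound 2 to compound 4 (0.97 log units; beyond the scatter) shows. No measurement at hand accounts for these steps.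

Still open, going by these compounds, is whether trifluoromethyl holds the number of compound 2 when carried as 3-(trifluoromethyl)phenyl, and whether a simpler 4-hydroxyphenyl or 4-methoxyphenyl would read with compound 1 or with the two fluorophenyl compounds. On these data alone, how an amine or a carboxylic acid on this ring would read in this assay also remains open.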